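Bromo in Place of Fluoro on the Aryl Urea

A few compounds are considered here, and "the series" means these few. Any claim that something is new, unique, unknown or untested is made for them only; others in the source may bear on it.

Compound 2 `O=C(Nc1cccc(F)c1)N[C@H]1CC[C@H](Oc2ccc(F)cc2)CC1` stands highest of the two numbers in a functional assay on CRL2813 cells (Homo sapiens) for cytotoxicity, read by sulforhodamine B assay, with a stated time of 5 days (a higher number here means a weaker inhibitor, a lower number a stronger inhibitor), where compound 2 gives 8300 nM. Going by the values given here, compound 3 `O=C(Nc1ccc([N+](=O)[O-])cc1)N[C@H]1CC[C@H](Oc2ccc(F)cc2)CC1` gives 2300 nM in this assay, and the step of a 3.6-fold lower number from compound 2 to compound 3 (0.56 log units; beyond the scatter) is the only measured change on the aryl urea. Compound 1 `O=C(Nc1cccc(C(F)(F)F)c1)N[C@H]1CC[C@H](O)CC1` reaches only a limit in this assay, > 20000 nM, which is the limit of > 20000 nM in this assay, at which 1 of the 3 values shown sits. Compound 4 `O=C(Nc1cccc(Br)c1)N[C@H]1CC[C@H](Oc2ccc(F)cc2)CC1` differs from compound 2 by bromo in place of fluoro on an aromatic carbon. Among the compounds with values here, no measured step replaces fluoro by bromo, and the one step on that ring moved the number down only modestly. Compound 4 is therefore expected to give 6000 nM, between 2500 nM and 15000 nM. This expected step a 1.4-fold lower number from compound 2 to compound 4 (0.14 log units; within the scatter) is estimated to stay close to the scatter.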

Compound 4, half-maximal inhibitory concentration: 6200 nM
The estimate for compound 4 lay 1.0-fold (0.01 log units) below the measured number; the measured number falls inside the stated range.
By their numbers in this assay, from the lowest: compound 3; then compounds 4 and 2 (each within the scatter of the next). At a limit, above all of these: compound 1.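

In this assay, the exchange of fluoro for bromo on this aromatic carbon stays within the scatter (a 1.3-fold lower number from compound 2 to compound 4 (0.13 log units; within the scatter)), so the two halogens are not told apart at this position. The 4-nitrophenyl urea remains separate from the 3-bromophenyl urea (a 2.7-fold higher number from compound 3 to compound 4 (0.43 log units; beyond the scatter)), so bromo does not close the earlier step. Nothing measured here gives a reason for either step. On these data alone, how an amine, a methoxy group or a nitrile at this position would compare stays open. Also open, as far as these compounds go, is whether the difference of compound 3 follows from the nitro group itself or from where it sits.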